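The source may hold more compounds than are shown below. What is called first, only, known or untested is meant among the compounds shown, and "the series" means these compounds.

Measured in a functional assay on CCRF-CEM cells (Homo sapiens) for cytotoxicity, in the presence of a further agent that is not named here; on this read-out lower numbers stand for stronger inhibition and higher numbers for weaker inhibition:

Compound 1 `CC(C)(C)OC(=O)CCC(Nc1ccc(CN(CCCc2c(N)nc(N)nc2O)c2ccc([N+](=O)[O-])c(F)c2[N+](=O)[O-])cc1)C(=O)OC(C)(C)C`: 4000 nM
Compound 2 `Nc1nc(N)c(CCCN(Cc2ccc(NC(CCC(=O)O)C(=O)O)cc2)c2cc(F)c(F)cc2[N+](=O)[O-])c(O)n1`: > 100000 nM, a limit of the assay
Compound 3 `Nc1nc(N)c(CCCN(Cc2ccc(NC(CCC(=O)O)C(=O)O)cc2)c2ccc([N+](=O)[O-])c(F)c2F)c(O)n1`: > 100000 nM, a limit of the assay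

Compound 3 has no exact number and stands only at the limit of > 100000 nM in this assay, at which 2 of the 3 values shown sit. Compound 4 `Nc1nc(N)c(CCCN(Cc2ccc(NC(CCC(=O)O)C(=O)O)cc2)c2cc(F)ccc2[N+](=O)[O-])c(O)n1` is reached through this change: 5-fluoro-2-nitrophenyl in place of 2,3-difluoro-4-nitrophenyl on an amine nitrogen. In words, 5-fluoro-2-nitrophenyl replaces 2,3-difluoro-4-nitrophenyl on an amine nitrogen. Within the data shown here, the one measured step that exchanges the group at this place is a step that the two limits leave unreadable from compound 2 to compound 3. It offers no readable size, so no change beyond the scatter is expected in this assay. The expected step is a number no higher from compound 3 to compound 4 (the limit leaves the size open). Compound 4 is estimated at 100000 nM, with an expected range from 30000 nM to 300000 nM.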

Compound 4, half-maximal inhibitory concentration: > 100000 nM
Compound 4 was reported as a limit (the forecaster's own chance of this, stated with the estimate: 75%); the middle value sits exactly at the limit.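

Among these compounds, compound 2, compound 3 and compound 4 all stand only at a limit, so no step among them can be read: the limit of > 100000 nM in this assay, at which 3 of the 4 values shown sit. As far as these compounds go, whether the fluorinated nitrophenyl groups of these three compounds differ at all in cytotoxicity stays open.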